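Two amides without measurable inhibition, and a third to be judged

The source may report more compounds than this note shows. Statements on the series, on what has been measured and on what is new or still open speak of the compounds shown alone.

Compound 1 `O=C(/C=C/c1coc2cc(O)ccc2c1=O)NCc1ccccc1` in a functional assay on L02 cells (Homo sapiens) for inhibition, read by MTT assay, with a stated time of 48 h; a lower number here means a stronger inhibitor, a higher number a weaker inhibitor: > 200000 nM, a limit of the assay rather than a number.
Compound 2 `COc1ccc(NC(=O)/C=C/c2coc3cc(O)ccc3c2=O)cc1` in this assay: > 200000 nM, likewise a limit of the assay.

Compound 2 therefore stands only at a limit in this assay: no number exists for it, and the same holds for compound 1, since both values sit at the limit of > 200000 nM in this assay, at which 2 of the 2 values shown sit. Going by the values given here, the one measured step, a step that the two limits leave unreadable from compound 1 to compound 2, is unreadable for that reason, so it gives no guide to how a change on the amide-type nitrogen alters inhibition.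

Compound 3 `Cc1ccccc1NC(=O)/C=C/c1coc2cc(O)ccc2c1=O` differs from compound 2 in that (2-methylphenyl in place of 4-methoxyphenyl on an amide-type nitrogen). Among the compounds with values here, the only step that bears on this position is the unreadable one from compound 1 to compound 2, so no size or direction can be taken from it. With both neighbours sitting at a limit, compound 3 is expected to remain at or beyond that limit as well, a step that the limit leaves unreadable from compound 2 to compound 3 being the estimate.

For compound 3 in this assay the estimate is 300000 nM, within a range from 100000 nM to 1000000 nM.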

Compound 3, half-maximal inhibitory concentration: > 200000 nM
Compound 3 gave a limit, no number (the forecaster's own chance of this, stated with the estimate: 85%); the middle value is on the limit's open side.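

In this assay compound 3 gives > 200000 nM as a limit of the assay and not a number. Going by these compounds alone, no step among compound 1, compound 2 and compound 3 can be read, since all three values stand alike: (the limit of > 200000 nM in this assay, at which 3 of the 3 values shown sit). These compounds leave open whether any change on the amide-type nitrogen alters inhibition at all.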